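The source may report more compounds than this note shows. Statements on the series, on what has been measured and on what is new or still open speak of the compounds shown alone.

Going by the values given here, compound 3 `O=C(NCCCOc1cccc(CN2CCCCC2)c1)Nc1cccc(C(F)(F)F)c1` gives 813 nM in an assay on isolated protein for inhibition of histamine H2 receptor (Cavia porcellus) (a higher number here means weaker binding, a lower number tighter binding), and so carries the highest of the three numbers measured so far. Compound 2 `Cc1ccc(NC(=O)NCCCOc2cccc(CN3CCCCC3)c2)cc1` gives 631 nM in this assay, and the pair sits together: a 1.3-fold higher number from compound 2 to compound 3 (0.11 log units; within the scatter). Compound 1 `CC(C)CNC(=O)NCCCOc1cccc(CN2CCCCC2)c1` gives 170 nM in this assay and stands apart from both, with a 4.8-fold higher number from compound 1 to compound 3 (0.68 log units; beyond the scatter) and a 3.7-fold higher number from compound 1 to compound 2 (0.57 log units; beyond the scatter).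

Compound 4 `CCCNC(=O)NCCCOc1cccc(CN2CCCCC2)c1` differs from compound 3 in one place: propyl in place of 3-(trifluoromethyl)phenyl on an amide-type nitrogen. The change thus undoes the aryl-for-isobutyl swaps seen in the measured steps, with a propyl chain where compound 1 carried isobutyl.

The steps from compound 1 to compound 3 and from compound 1 to compound 2 both bear on this: each time a six-membered aromatic ring replaced the isobutyl chain, the number rose modestly and beyond the scatter. Putting a chain back in place of the ring is therefore expected to lower the number by a step of about the same size, i.e. a 4.1-fold lower number from compound 3 to compound 4 (0.61 log units; beyond the scatter), bringing compound 4 near compound 1. The estimate for compound 4 in this assay is 200 nM, with a range from 80 nM to 500 nM.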

Compound 4, dissociation constant: 97.7 nM
Compound 4: the middle estimate sits 2.0-fold (0.31 log units) above what was measured; the range from low to high includes it.
By their numbers in this assay, from the lowest: compounds 4 and 1 (each within the scatter of the next); then compounds 2 and 3 (each within the scatter of the next).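

In this assay, going by these compounds alone, the change from a six-membered aromatic ring back to a chain on the amide-type nitrogen gives an 8.3-fold lower number from compound 3 to compound 4 (0.92 log units; beyond the scatter) and a 6.5-fold lower number from compound 2 to compound 4 (0.81 log units; beyond the scatter) in the series, so the separation between chains and aromatic rings at this place now holds for propyl as well as for isobutyl, with no compound among the four going against it. The branch on the chain carries no readable weight here: a 1.7-fold lower number from compound 1 to compound 4 (0.24 log units; within the scatter) for the removal of one methyl, and compound 1 and compound 4 sit together. No measurement shown accounts for the difference between the chains and the aromatic rings.

Whether the lower numbers follow from the absence of an aromatic ring or from the open-chain shape stays unsettled, and a cyclohexyl group at this place would separate the two readings. On these data alone, how far the chain result extends also stays open, since methyl and a longer chain such as hexyl would show whether the numbers stay with those of compound 1 and compound 4 or move away.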